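This account rests on a few compounds, and the source may have more. Where it says the series, first, only, none or still open, it means among the compounds named here.

Compounds measured:
compound 1, `COc1ccc(-c2nc(CN(C)C)sc2-c2ccc(OC)cc2)cc1`: 8.4 uM
compound 2, `COc1ccc(-c2nc(C(=O)N3CCNC(CCO)C3)sc2-c2ccc(OC)cc2)cc1`: 9.5 uM

Both numbers come from a functional assay (aorta) with Rattus norvegicus as the target; on this read-out lower numbers stand for an effect already at smaller amounts and higher numbers for an effect only at larger amounts of compound. In this assay compound 1 gives 8.4 uM, the lowest of the two numbers, and compound 2 gives 9.5 uM, a gap that lies within the scatter, so neither compound stands apart from the other. Compound 3, `COc1ccc(-c2nc(/C=C/C(=O)O)sc2-c2ccc(OC)cc2)cc1`, has not yet been measured. It differs from compound 1 in one place: 2-carboxyethenyl in place of (dimethylamino)methyl on an aromatic carbon. Within the data shown here, no step between measured compounds that differ in one place is available, so the size of this change is not anchored by any measured pair. Since compound 1 and compound 2 sit together in this assay despite carrying different groups on the same aromatic carbon, the change is expected to move the number only modestly. The estimated step is a 1.8-fold higher number from compound 1 to compound 3 (0.25 log units; within the scatter), small and if anything toward a higher number. Compound 3 is expected to give 15 uM, with a range from 4 uM to 60 uM.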

Compound 3, concentration for half-maximal effect: 55 uM
Compound 3: middle estimate off by 3.7-fold (0.56 log units), on the low side, and the stated range covers the measured number.
By their numbers in this assay, from the lowest: compounds 1 and 2 (each within the scatter of the next); then compound 3.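

Replacing (dimethylamino)methyl with 2-carboxyethenyl on this aromatic carbon, which lies next to the ring nitrogen and next to the ring sulfur, gives a 6.5-fold higher number from compound 1 to compound 3 (0.82 log units; beyond the scatter) in this assay. Among these compounds, this is the first measured step at the position, and it shows that the group held here can move the number beyond the scatter, which the closely matched values of the two earlier compounds gave no sign of. Nothing measured here accounts for the step, and the two groups differ in more than one feature, so the shift cannot be assigned to any one of them.

The compounds shown do not separate the carboxylic acid from its ethenyl link, which a saturated 2-carboxyethyl chain or a methyl ester on the same carbon could address. They also leave open how a longer amine chain or a plain methyl group would compare with compound 1.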